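The source may hold more compounds than are shown below. What is called first, only, known or untested is meant among the compounds shown, and "the series" means these compounds.

Two compounds in this series have a number in a functional assay on the whole organism (Tail, strain ICR) with Mus musculus as the target, in the tail flick test, with a stated time of 120 min, at a dose of 25 umol/kg by the oral route; on this read-out higher numbers stand for a stronger effect at the one dose given and lower numbers for a weaker effect. Compound 1, `O=C(CN(c1ncnc2c1ncn2C1CCCCO1)C1CC1)N[C@@H](CO)C(=O)OCc1ccccc1`, gives 29.2%. Compound 2, `NCCCC[C@H](NC(=O)CN(c1nc(Cl)nc2[nH]cnc12)C1CC1)C(=O)OCc1ccccc1`, gives 16.8%, the lower of the two numbers, and its gap to compound 1 lies beyond the usual scatter of this measurement. The unmeasured compound 3, `C[C@@H](O)[C@H](NC(=O)CN(c1nc(Cl)nc2[nH]cnc12)C1CC1)C(=O)OCc1ccccc1`, keeps the core of compound 2 and differs from it in one place: 1-hydroxyethyl in place of 4-aminobutyl on a saturated chain carbon bound to an amide-type nitrogen and a carbonyl carbon. Among the compounds with values here, compound 1 differs from compound 2 both in its core and in its side chain, so no step that isolates this single change is known. With only that to go on, the step from compound 2 to compound 3 is expected to be small and upward, a number 6.2 percentage points higher from compound 2 to compound 3 (within the scatter), of a size at the edge of the scatter. Compound 3 is therefore estimated to give 23%, with a range from 9% to 38%.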

Compound 3, a percentage reported as activity, at one dose (the size of the read-out at that dose, not a potency): 30.7%
Compound 3: middle estimate off by 7.7 percentage points, on the low side; measured number inside the range.
By their numbers in this assay, from the lowest: compound 2; then compounds 1 and 3 (each within the scatter of the next).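

Holding the core of compound 2 fixed, 1-hydroxyethyl in place of 4-aminobutyl on a saturated chain carbon bound to an amide-type nitrogen and a carbonyl carbon gives a number 13.9 percentage points higher from compound 2 to compound 3 (beyond the scatter) in this assay. Within the data shown here, this is the first step that isolates one place, and it shows that the group at this position can move the read-out at the single dose given. Nothing measured here explains the step.

The change removes the nitrogen and adds an oxygen while also shortening the group and adding a defined stereocentre, so these features remain unseparated. A plain ethyl group, a 4-hydroxybutyl chain or the opposite stereocentre of 1-hydroxyethyl at this position would help tell them apart.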